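The source may hold more compounds than are shown below. What is called first, only, known or untested is meant among the compounds shown, and "the series" means these compounds.

Measured compounds:
- compound 1 `O=Cc1ccc(-c2cn3ccnc3c(-c3ccc4ncn(C5CCCCC5)c4c3)n2)cc1`: 4.21%
- compound 2 `c1ccc2c(-c3cn4ccnc4c(-c4ccc5ncn(C6CCCCC6)c5c4)n3)cccc2c1`: 5.34%
- compound 3 `Clc1ccc(-c2cn3ccnc3c(-c3ccc4ncn(C5CCCCC5)c4c3)n2)cc1`: 14%

In a functional assay on SW-620 cells (Homo sapiens) for inhibition, read by sulforhodamine B assay, with a stated time of 48 h, tested at 10 uM (a lower number here means less inhibition, a higher number more inhibition at the concentration tested (going by the name of the read-out)), compound 3 stands highest of the three numbers, but the gaps to its neighbours are small: a number 8.7 percentage points higher from compound 2 to compound 3 (within the scatter) and a number 9.8 percentage points higher from compound 1 to compound 3 (within the scatter) are both within the scatter, so the number for compound 3 cannot be called higher than that of compound 2 or compound 1 on these data. The three compounds share one core and differ only in the aryl group on the same aromatic carbon.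

Compound 4 `COc1ccccc1-c1cn2ccnc2c(-c2ccc3ncn(C4CCCCC4)c3c2)n1` continues this series: 2-methoxyphenyl in place of 4-chlorophenyl on an aromatic carbon. All three measured steps bear on this kind of change, since each swaps one aryl group for another at that position, and every one of them, a number 1.1 percentage points higher from compound 1 to compound 2 (within the scatter) as much as a number 9.8 percentage points higher from compound 1 to compound 3 (within the scatter) and a number 8.7 percentage points higher from compound 2 to compound 3 (within the scatter), stayed within the scatter. No measured compound carries a methoxy group, so the new substituent is untested, but the record gives no reason to expect a step beyond the scatter. Compound 4 is therefore expected to show a number 4 percentage points lower from compound 3 to compound 4 (within the scatter) in this assay, an estimate of 10% with a range from 0% to 25%.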

Compound 4, a percentage reported as inhibition, at one concentration (the size of the read-out at that concentration, not a potency): 3.4%
Compound 4: middle estimate off by 6.6 percentage points, on the high side; the measured number falls inside the stated range.
By their numbers in this assay, from the lowest: compounds 4, 1, 2 and 3 (each within the scatter of the next, the first and the last beyond it).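

In this assay this position gives its first step beyond the scatter, a number 10.6 percentage points lower from compound 3 to compound 4 (beyond the scatter), so the aryl group placed here can shift the number, though only modestly. The same group shows no such separation from the other two aryl groups, with a number 1.9 percentage points lower from compound 2 to compound 4 (within the scatter) and a number 0.8 percentage points lower from compound 1 to compound 4 (within the scatter) both within the scatter, which makes the 4-chlorophenyl and 2-methoxyphenyl pair the only separated one in the series. No available evidence accounts for this step.

The compounds shown leave open whether the step follows the loss of the chloro group, the arrival of the methoxy group or the different place of each on the phenyl ring. They also leave open how an aryl group carrying an amine or a carboxylic acid would read in this assay at this position.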